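Replacing the aryl carbonyl with a cyclopropylsulfonyl group

The source may report more compounds than this note shows. Statements on the series, on what has been measured and on what is new or still open speak of the compounds shown alone.

Measured so far in a functional assay on HCC1806 cells (Homo sapiens) for inhibition, read by sulforhodamine B assay, tested at 10 uM; a lower number here means less inhibition, a higher number more inhibition at the concentration tested (going by the name of the read-out):
compound 1, `CN1CCN(c2ccc(C3=NN(C(=O)CCCl)C(c4ccc(N(C)C)cc4)C3)cc2)CC1`, gives 1.7%
compound 2, `Cc1ccc(C(=O)N2N=C(c3ccc(N4CCN(C)CC4)cc3)CC2c2ccc(N(C)C)cc2)cc1`, gives -2.5%
compound 3, `CN1CCN(c2ccc(C3=NN(C(=O)c4ccc(C(F)(F)F)cc4)C(c4ccc(N(C)C)cc4)C3)cc2)CC1`, gives 84.1%

Compound 3 stands highest of the three numbers. The two steps leading to it, a number 82.4 percentage points higher from compound 1 to compound 3 (beyond the scatter) and a number 86.6 percentage points higher from compound 2 to compound 3 (beyond the scatter), are both large and beyond the scatter, whereas a number 4.2 percentage points lower from compound 1 to compound 2 (within the scatter) stays within it. The high reading of compound 3 therefore goes with the (4-(trifluoromethyl)phenyl)carbonyl group, which is absent from the two low-reading compounds.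

Compound 4, `CN1CCN(c2ccc(C3=NN(S(=O)(=O)C4CC4)C(c4ccc(N(C)C)cc4)C3)cc2)CC1`, differs from compound 3 by cyclopropylsulfonyl in place of (4-(trifluoromethyl)phenyl)carbonyl on an amine nitrogen in a ring. For the measured compounds named here, the steps that bear on this change are a number 82.4 percentage points higher from compound 1 to compound 3 (beyond the scatter) and a number 86.6 percentage points higher from compound 2 to compound 3 (beyond the scatter): both show that the group now leaving is what lifts compound 3 above the rest. Going by the values given here, the entering cyclopropylsulfonyl group appears in none of the measured compounds, so its own contribution is unknown. With the group that carried the high reading removed, compound 4 is expected to drop strongly, a number 69.1 percentage points lower from compound 3 to compound 4 (beyond the scatter), toward the values of the small-acyl analogues. The estimate for compound 4 in this assay is 15%, expected to lie between -5% and 55%.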

Compound 4, a percentage reported as inhibition, at one concentration (the size of the read-out at that concentration, not a potency): 4.7%
Compound 4: the middle estimate sits 10.3 percentage points above what was measured; the measured number falls inside the stated range.
By their numbers in this assay, from the lowest: compounds 2, 1 and 4 (each within the scatter of the next); then compound 3.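

In this assay, the step of a number 79.4 percentage points lower from compound 3 to compound 4 (beyond the scatter) shows that a cyclopropylsulfonyl group on this amine nitrogen in a ring does not keep the high reading that goes with the (4-(trifluoromethyl)phenyl)carbonyl group. With a number 7.2 percentage points higher from compound 2 to compound 4 (within the scatter) and a number 3 percentage points higher from compound 1 to compound 4 (within the scatter), compound 4 joins the low-reading group, so three different groups at this place now give readings within the scatter of one another, and only the (4-(trifluoromethyl)phenyl)carbonyl group of compound 3 stands apart. Nothing measured here explains this drop, and the change replaces both the carbonyl and the aromatic ring at once, so the step cannot assign it to either one.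

Open, on these data alone, is how a (4-(trifluoromethyl)phenyl)sulfonyl group or a cyclopropylcarbonyl group would read on this nitrogen, since either would separate the link to the nitrogen from the group it carries. Also open, as far as these compounds go, is whether the reading depends on trifluoromethyl itself, or whether a chlorine or a nitrile on the same aromatic ring would give a similar number.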